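Truncating the side chain of a diterpenoid antiproliferative series

A few compounds are considered here, and "the series" means these few. Any claim that something is new, unique, unknown or untested is made for them only; others in the source may bear on it.

Working notes on three measured compounds and one still open. In a functional assay on HL-60 cells (Homo sapiens) for antiproliferative activity, read by trypan blue exclusion (on this read-out lower numbers stand for stronger inhibition of growth and higher numbers for weaker inhibition of growth), compound 1 `C=C1CC[C@@H]2[C@](C)(CO)[C@H](O)CC[C@@]2(C)[C@@H]1C[C@H](O)[C@@H]1C(=O)OC[C@H]1O` gives 24400 nM. In this assay compound 2 `C=C1CC[C@@H]2[C@](C)(CO)CCC[C@@]2(C)[C@@H]1CC/C(=C/CO)CO` gives 20400 nM. In this assay compound 3 `C=C1CC[C@@H]2[C@](C)(CO)[C@H](O)CC[C@@]2(C)[C@@H]1CC/C(=C/CO)C(=O)O` gives 22400 nM. Compound 3 sits with the other two in a narrow band: its gap to compound 1 and its gap to compound 2 both lie within the usual scatter, so the three numbers cannot be ordered against one another, and all of them describe weak inhibition of growth. Within the data shown here, no pair among the measured compounds differs in a single place, so no measured step exists to calibrate the next change.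

Compound 4 `C=C1CC[C@@H]2[C@](C)(CO)[C@H](O)CC[C@@]2(C)[C@@H]1CCC(=O)O` is the open case. Relative to compound 3 the change is a group of 3 heavy atoms (1 carbon, 2 oxygen; no ring) in place of a group of 7 heavy atoms (4 carbon, 3 oxygen; no ring), on a saturated chain carbon, two bonds along the chain from a saturated ring carbon. The side chain is thus shortened to a carboxy group while the shared core and its hydroxyls stay as they are. Among the measured compounds shown here, with no measured single-place step, the expectation for this assay is a step no larger than the scatter, if anything toward weaker inhibition, since the three measured compounds with longer side chains already cluster at weak inhibition. Compound 4 is therefore estimated at 32000 nM, within a range from 12000 nM to 85000 nM, which means an expected step of a 1.4-fold higher number from compound 3 to compound 4 (0.15 log units; within the scatter).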

Compound 4, concentration for 50% growth inhibition: 25000 nM
Compound 4: middle estimate off by 1.3-fold (0.11 log units), on the high side; measured number inside the range.
By their numbers in this assay, from the lowest: compounds 2, 3, 1 and 4 (each within the scatter of the next).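

In this assay the series now has its first measured single-place step, a 1.1-fold higher number from compound 3 to compound 4 (0.05 log units; within the scatter), and it lies within the scatter. At this saturated chain carbon, two bonds along the chain from a saturated ring carbon, a carboxy group can therefore stand in place of the group of 7 heavy atoms (4 carbon, 3 oxygen; no ring) without a change that can be told from repeat measurement. For this one pair, then, the larger group, with its 2 double bonds outside aromatic rings, is not needed to keep the number where it stands, though no data here explain why the step is so small.

On these data alone, whether any group at this place can move the number beyond the scatter stays open, and an amine, a primary amide or a methyl ester in place of the carboxy group would put that to the test. The step also leaves the shared core and its hydroxyls untouched, so it gives no information on what changes there would do.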